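The source may hold more compounds than are shown below. What is called first, only, known or untested is meant among the compounds shown, and "the series" means these compounds.

Compound 1 `CCN(Cc1ccccc1)C(=O)C1CCN(S(=O)(=O)c2ccc(OC)c(OC)c2)CC1` and compound 2 `CCN(Cc1ccccc1)C(=O)C1CCN(S(=O)(=O)c2ccc(C(F)(F)F)nc2)CC1` share a core that carries a sulfonyl group. In a functional assay on CHO cells for positive allosteric modulation of muscarinic acetylcholine receptor M5 (Homo sapiens), read by calcium flux (a lower number here means a smaller maximal response, a higher number a larger maximal response), compound 1 gives 57%, whereas compound 2 gives "not determined" (no result reported), so compound 2 stands nowhere on the scale. The move to compound 3 `CCN(Cc1ccccc1)C(=O)C1CCN(S(=O)(=O)c2ccc3nsnc3c2)CC1` changes only the group on the sulfonyl sulfur: a group of 9 heavy atoms (6 carbon, 2 nitrogen, 1 sulfur; one five-membered aromatic ring with 3 hetero atoms, one six-membered aromatic ring of carbon only) in place of a group of 10 heavy atoms (6 carbon, 1 nitrogen, 3 fluorine; one six-membered aromatic ring with 1 hetero atom), on a sulfonyl sulfur. Among the compounds with values here, no measured step in this assay exists for such a change, so no size or direction can be read from the data beyond the scatter. Compound 3 is expected to give roughly 55% in this assay, within a range from 30% to 85%.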

Compound 3, largest response reached (reported as percent of maximum), in percent of the reference or control that the assay uses: 81%
Estimate against measurement, compound 3: 26 percentage points below; measured number inside the range.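

In this assay the sulfonyl sulfur accepts a two-ring group, a five-membered aromatic ring with 3 hetero atoms plus a six-membered aromatic ring of carbon only, with a number 24 percentage points higher from compound 1 to compound 3 (beyond the scatter) for this swap of one group. Compound 2 has no number, so its steps cannot be read. Nothing measured here explains the rise.

Still open, as far as these compounds go, is how other groups on this sulfur would behave, such as a plain butyl chain or a phenyl ring carrying an amine or a carboxylic acid.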